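Exchanging One Group on an Amine Nitrogen

A few compounds are considered here, and "the series" means these few. Any claim that something is new, unique, unknown or untested is made for them only; others in the source may bear on it.

Among the measured compounds shown here, in a functional assay on Pfeiffer cells (Homo sapiens) for cytotoxicity, read by scintillation counting and thymidine incorporation, with a stated time of 4 days (on this read-out lower numbers stand for stronger inhibition and higher numbers for weaker inhibition), compound 1 `COc1c([C@H](C)Nc2ncnc(N)c2C#N)cc(Cl)c(C)c1-c1ccc(C(=O)N(C)C)cn1` gives 17 nM and compound 2 `COc1c([C@H](C)Nc2ncnc3[nH]cnc23)cc(Cl)c(C)c1-c1cncc(S(C)(=O)=O)c1` gives 9.5 nM so that compound 2 stands within the usual scatter of the only other measured value. For the measured compounds named here, these two compounds differ in more than one place, and no single-place step has been measured. Compound 3 `COc1c([C@H](C)Nc2ncnc(N)c2C#N)cc(Cl)c(C)c1-c1cncc(S(C)(=O)=O)c1` differs from compound 2 by one exchange, a group of 9 heavy atoms (5 carbon, 4 nitrogen; one six-membered aromatic ring with 2 hetero atoms) in place of a group of 9 heavy atoms (5 carbon, 4 nitrogen; one five-membered aromatic ring with 2 hetero atoms, one six-membered aromatic ring with 2 hetero atoms), on an amine nitrogen and the group that enters is 6-amino-5-cyanopyrimidin-4-yl. Compound 1 carries that same group and gives 17 nM in this assay and so no change beyond the scatter is expected in either direction. The estimated step of a 1.1-fold lower number from compound 2 to compound 3 (0.02 log units; within the scatter) is therefore small. Compound 3 is expected at 9 nM in this assay with an estimated range from 3 nM to 30 nM for repeated measurements.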

Compound 3, half-maximal inhibitory concentration: 3.4 nM
Compound 3: the middle estimate sits 2.6-fold (0.42 log units) above what was measured; the measured number falls inside the stated range.
By their numbers in this assay, from the lowest: compound 3; then compounds 2 and 1 (each within the scatter of the next).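

In this assay the exchange on an amine nitrogen that brings in 6-amino-5-cyanopyrimidin-4-yl gives a 2.8-fold lower number from compound 2 to compound 3 (0.45 log units; beyond the scatter) and thus provides the first single-place comparison, showing that the group on this nitrogen changes the number. The exchange of 5-(dimethylcarbamoyl)pyridin-2-yl for 5-(methylsulfonyl)pyridin-3-yl on an aromatic carbon gives a 5.0-fold lower number from compound 1 to compound 3 (0.70 log units; beyond the scatter) and shows that the number also responds at this second place. Nothing measured here explains either step.

The compounds shown leave open which part of 6-amino-5-cyanopyrimidin-4-yl carries the step, since no group on the amine nitrogen has the amino group or the nitrile alone. They also leave open whether a pyridin-3-yl bearing a carboxylic acid in place of methylsulfonyl would keep the number of compound 3.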